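Swapping trifluoromethyl for methyl on the outer ring

The source may report more compounds than this note shows. Statements on the series, on what has been measured and on what is new or still open speak of the compounds shown alone.

Three measured compounds share one core and differ only in the group on the outer phenyl ring. Compound 1 `COc1cc(-n2cnc3ccc(-c4ccc(C(F)(F)F)cc4)cc32)cc(OC)c1OC` carries a trifluoromethyl there and in a functional assay on A549 cells (Homo sapiens) for antiproliferative activity, read by MTT assay, with a stated time of 72 h (on this read-out higher numbers stand for weaker inhibition and lower numbers for stronger inhibition), gives 3390 nM, the lowest of the two plain numbers recorded. Compound 3 `COc1cc(-n2cnc3ccc(-c4ccc(F)cc4)cc32)cc(OC)c1OC` carries a fluoro instead and gives 6740 nM in this assay. Compound 2 `COc1cc(-n2cnc3ccc(-c4ccc(Cl)cc4)cc32)cc(OC)c1OC` carries a chloro and gives > 10000 nM in this assay; that value is a limit of the measurement rather than a number, namely (the limit of > 10000 nM in this assay, at which 1 of the 3 values shown sits).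

The step of a 2.0-fold higher number from compound 1 to compound 3 (0.30 log units; within the scatter) stays within the usual scatter, whereas an at least 2.9-fold higher number from compound 1 to compound 2 (0.46 log units; beyond the scatter) is a loss beyond it. Both replacements of the trifluoromethyl therefore moved the number upward, one clearly and one not. Compound 4 `COc1cc(-n2cnc3ccc(-c4ccc(C)cc4)cc32)cc(OC)c1OC` is the untested partner of compound 1: methyl in place of trifluoromethyl on an aromatic carbon. With only these two steps to lean on, a modest rise in this assay is expected for compound 4, probably larger than the step to compound 3 but not necessarily reaching the limit seen for compound 2.

Compound 4 is expected to give about 7000 nM in this assay, with a likely range from 2500 nM to 20000 nM. That estimate amounts to a 2.1-fold higher number from compound 1 to compound 4 (0.31 log units; beyond the scatter).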

Compound 4, half-maximal inhibitory concentration: 1940 nM
The estimate for compound 4 lay 3.6-fold (0.56 log units) above the measured number, and the stated range ends above it.
By their numbers in this assay, from the lowest: compounds 4, 1 and 3 (each within the scatter of the next, the first and the last beyond it). At a limit, above all of these: compound 2.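

In this assay, methyl and trifluoromethyl cannot be told apart at this place, on an aromatic carbon para to a large group: a 1.7-fold lower number from compound 1 to compound 4 (0.24 log units; within the scatter). The earlier compounds shown here showed only replacements of trifluoromethyl that moved the number upward, whereas the methyl replacement brings no loss, and it also separates from the fluoro compound, as a 3.5-fold lower number from compound 3 to compound 4 (0.54 log units; beyond the scatter), and from the chloro compound, as an at least 5.1-fold lower number from compound 2 to compound 4 (0.71 log units; beyond the scatter). That last step is only a floor, as the value for compound 2 is a limit and not a number: the limit of > 10000 nM in this assay, at which 1 of the 4 values shown sits.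

The groups shown at this place are only methyl, trifluoromethyl, fluoro and chloro, so it stays open whether a methoxy group, an amine, a carboxylic acid or a longer chain such as propyl would match compound 4 or fall back towards compound 3. From the compounds shown here alone, it also stays open whether any group here could bring a step beyond the scatter below compound 4, and whether the methyl result would hold on a different core.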